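Tosylating the Phenol of Compound 3

The source may hold more compounds than are shown below. What is called first, only, known or untested is meant among the compounds shown, and "the series" means these compounds.

Compound 3 `C=C1C(=O)[C@]23C[C@@]1(O)CC[C@H]2c1ccc(O)c(C)c1[C@@H]3Cn1cc(-c2ccccn2)nn1` carries a free hydroxy on its aromatic ring and a pyridin-2-yl on its triazole. In a functional assay on MCF7 cells (Homo sapiens) for cytotoxicity, read by MTT assay, with a stated time of 4 days (a higher number here means a weaker inhibitor, a lower number a stronger inhibitor), compound 3 gives 2240 nM, the highest of the three measured numbers. Its nearest neighbour is compound 2 `C=C1C(=O)[C@]23C[C@@]1(O)CC[C@H]2c1ccc(OS(=O)(=O)c2ccc(C)cc2)c(C)c1[C@@H]3Cn1cc(-c2ccc(F)cc2)nn1`, which in this assay gives 330 nM, and compound 1 `C=C1C(=O)[C@]23C[C@@]1(O)CC[C@H]2c1ccc(OS(=O)(=O)c2ccc(C)cc2)c(C)c1[C@@H]3Cn1cc(-c2ccc(C)cc2)nn1` gives 320 nM; both of these carry the ((4-methylphenyl)sulfonyl)oxy group where compound 3 has the hydroxy, and both lie well below compound 3. Compound 4 `C=C1C(=O)[C@]23C[C@@]1(O)CC[C@H]2c1ccc(OS(=O)(=O)c2ccc(C)cc2)c(C)c1[C@@H]3Cn1cc(-c2ccccn2)nn1` is compound 3 with (4-methylphenyl)sulfonyl in place of hydrogen on an oxygen on an aromatic ring. Going by the values given here, no measured pair isolates this change. Among the compounds with values here, the only measured step, a 1.0-fold higher number from compound 1 to compound 2 (0.01 log units; within the scatter), shows that swapping the substituent on the aryl attached to the triazole leaves the number unchanged, so the triazole aryl alone is unlikely to account for the gap between compound 3 and the two tosylates. Within the data shown here, compound 4 is therefore expected to move toward the numbers of compounds 1 and 2, though the pyridin-2-yl has no measured counterpart among the tosylates, which widens the uncertainty. Compound 4 is estimated at 500 nM, with a range of 200 nM to 1500 nM. The expected step of a 4.5-fold lower number from compound 3 to compound 4 (0.65 log units; beyond the scatter) is a drop beyond the scatter.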

Compound 4, half-maximal inhibitory concentration: 320 nM
Beside the measured number, compound 4's estimate is 1.6-fold (0.19 log units) above it; the measured number falls inside the stated range.
By their numbers in this assay, from the lowest: compounds 1, 4 and 2 (each within the scatter of the next); then compound 3.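

In this assay, going by these compounds alone, the pair of compound 3 and compound 4 isolates the change from hydroxy to ((4-methylphenyl)sulfonyl)oxy on the aromatic ring, and it gives a 7.0-fold lower number from compound 3 to compound 4 (0.85 log units; beyond the scatter), a step that the earlier compounds could only suggest through comparisons that differed in more than one place. The aryl on the triazole stays silent with the ((4-methylphenyl)sulfonyl)oxy group in place: pyridin-2-yl in place of 4-fluorophenyl gives a 1.0-fold lower number from compound 2 to compound 4 (0.01 log units; within the scatter), and pyridin-2-yl in place of 4-methylphenyl gives no change at the digits printed from compound 1 to compound 4 (within the scatter), so among these three compounds the pyridin-2-yl, 4-fluorophenyl and 4-methylphenyl groups cannot be told apart. Nothing at hand explains why the change on the oxygen moves the number.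

The compounds shown leave open whether the step belongs to the sulfonyl or to its 4-methylphenyl part, which a methanesulfonyl, an acetyl or a plain methyl on the same oxygen would help to separate. Also open, from the compounds shown here alone, is whether the triazole aryl stays as silent with the free hydroxy, or when it carries an amine or a carboxylic acid.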